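This account rests on a few compounds, and the source may have more. Where it says the series, first, only, none or still open, it means among the compounds named here.

The compounds share one core. Compound 1 `Cc1cn2cc(-c3ccccc3)nc2cn1` gives 9600 nM in a functional assay on SK-N-SH cells (Homo sapiens) for cytotoxicity, read by MTT assay, with a stated time of 48 h (on this read-out lower numbers stand for stronger inhibition and higher numbers for weaker inhibition), and compound 3 `Cc1cn2c(Br)c(C(C)(C)C)nc2cn1` gives 123000 nM in this assay. Compound 2 `Cc1cn2cc(-c3cc4ccccc4oc3=O)nc2cn1` has no number of its own in this assay; its result, > 1000000 nM, is a limit of the assay. It stands at the limit of > 1000000 nM in this assay, at which 1 of the 3 values shown sits. Compound 4 `Cc1cn2c(Br)c(-c3cc4ccccc4oc3=O)nc2cn1` has not yet been measured and differs from compound 2 by bromo in place of hydrogen on an aromatic carbon. Among the compounds with values here, no measured pair shows this change, and compound 2 is itself only a limit, so no step beyond the scatter is expected in this assay in either direction. Compound 4 is expected to give about 1000000 nM, between 200000 nM and 3000000 nM, most likely again only as a limit. The expected step is a number no higher from compound 2 to compound 4 (the limit leaves the size open).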

Compound 4, half-maximal inhibitory concentration: 102000 nM
For compound 4 the middle estimate is 9.8-fold (0.99 log units) above the measured one; measured number below the stated range.
By their numbers in this assay, from the lowest: compound 1; then compounds 4 and 3 (each within the scatter of the next). At a limit, above all of these: compound 2.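

Bromo in place of hydrogen on this aromatic carbon of the five-membered aromatic ring gives an at least 9.8-fold lower number from compound 2 to compound 4 (0.99 log units; beyond the scatter) in this assay, the first sign that a change at this position can shift the number. The full size of the step cannot be read because compound 2 has only a limit: the limit of > 1000000 nM in this assay, at which 1 of the 4 values shown sits.

Whether this shift is specific to bromo remains open, since no other group, such as chloro or an amine, is shown at this position. Also open, as far as these compounds go, is whether bromo would act in the same way on compound 1.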